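Swapping the bromo of compound 1 for hydrogen

The source may report more compounds than this note shows. Statements on the series, on what has been measured and on what is new or still open speak of the compounds shown alone.

Values in a toxicity assay on Huh-7.5 cells (Homo sapiens) for inhibition, read by MTT assay, with a stated time of 96 h (on this read-out lower numbers stand for higher toxicity in this test and higher numbers for lower toxicity in this test), so far
- Compound 1 `CC(C)Oc1ccc(C(=O)Nc2ccc(N(C)C)cc2)cc1NC(=O)C(C)Br` gives 7900 nM
- Compound 2 `CCC(=O)Nc1cc(C(=O)Nc2ccc(CN3CCN(C)CC3)c(C(F)(F)F)c2)ccc1OC(C)C` gives 15300 nM
- Compound 3 `CCC(=O)Nc1cc(C(=O)Nc2ccc(-c3cc4ccccc4[nH]3)cc2)ccc1OC` gives 65600 nM

Compound 1 at 7900 nM lies within the usual scatter of compound 2 and clearly under compound 3 on this scale. Compound 4 `CCC(=O)Nc1cc(C(=O)Nc2ccc(N(C)C)cc2)ccc1OC(C)C` has not been measured yet. It differs from compound 1 in one place hydrogen in place of bromo on a saturated chain carbon bound to a carbonyl carbon and a saturated chain carbon with hydrogen in place of bromo on a saturated chain carbon bound to a carbonyl carbon and a saturated chain carbon, so (1-bromoethyl)carbonyl becomes propanoyl.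

Among the measured compounds shown here, no measured pair isolates this change, so the guide is indirect. Compound 2 at 15300 nM and compound 3 at 65600 nM both carry propanoylamino, as compound 4 does, though both differ from it elsewhere. In this assay a move to a higher number, meaning lower toxicity, is therefore expected, probably beyond the scatter. The expected move is a 3.8-fold higher number from compound 1 to compound 4 (0.58 log units; beyond the scatter) and it remains an estimate. For compound 4 the estimated value is 30000 nM with an expected range from 12000 nM to 90000 nM and the measurement will settle it.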

Compound 4, half-maximal cytotoxic concentration: 80600 nM
For compound 4 the middle estimate is 2.7-fold (0.43 log units) below the measured one; low and high end bracket the measured number.
By their numbers in this assay, from the lowest: compounds 1 and 2 (each within the scatter of the next); then compounds 3 and 4 (each within the scatter of the next).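

In this assay, among the compounds shown here, the single swap of hydrogen for bromo on a saturated chain carbon bound to a carbonyl carbon and a saturated chain carbon gives a 10-fold higher number from compound 1 to compound 4 (1.01 log units; beyond the scatter) and so marks a large drop in toxicity in this test. For the compounds shown here, compound 2 and compound 3 also carry propanoylamino but differ from compound 1 elsewhere too, so only this pair ties a change in toxicity to the bromo alone, with the rest of the molecule held fixed. No data at hand speak to what lies behind the size of this step.

Going by these compounds, whether a chloro or a hydroxyl on that carbon would behave like the bromo or like hydrogen stays open. So does the effect of a longer chain in place of the ethyl.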